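From vinyl to 4-bromophenyl at the assay limit

The source may report more compounds than this note shows. Statements on the series, on what has been measured and on what is new or still open speak of the compounds shown alone.

Of the compounds shown here, three that share one core have been tested in an ADME assay on L02 cells (Homo sapiens) for cytotoxicity, read by MTT assay (on this read-out lower numbers stand for stronger inhibition and higher numbers for weaker inhibition), so far. Compound 1 `COc1ccc(/C=C/C(=O)c2ccc(OC)c3c2OC(C)(C)C=C3)cc1OCC=C(C)C` gives > 10000 nM as its result, and this is a limit and not a number. Compound 2 `CCC(=O)Oc1cc(/C=C/C(=O)c2ccc(OC)c3c2OC(C)(C)C=C3)ccc1OC` gives > 10000 nM as its result, again a limit. Compound 3 `C=CC(=O)Oc1cc(/C=C/C(=O)c2ccc(OC)c3c2OC(C)(C)C=C3)ccc1OC` gives > 10000 nM as its result, also a limit. Compound 3 therefore stands with the other two, and the whole record is the limit of > 10000 nM in this assay, at which 3 of the 3 values shown sit, with no exact value among them.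

Compound 4 `COc1ccc(/C=C/C(=O)c2ccc(OC)c3c2OC(C)(C)C=C3)cc1OC(=O)c1ccc(Br)cc1` differs from compound 3 in one place, on a carbonyl carbon, where 4-bromophenyl takes the place of vinyl (4-bromophenyl in place of vinyl on a carbonyl carbon). The closest guide, at that same carbonyl carbon, is a step that the two limits leave unreadable from compound 2 to compound 3 and it offers no size. The changes on an oxygen on an aromatic ring are a step that the two limits leave unreadable from compound 1 to compound 2 and a step that the two limits leave unreadable from compound 1 to compound 3 and neither of them offers a size either. Among the measured compounds shown here, no measured step points in a direction, so in this assay the expectation is simply that compound 4 stays with the others. The expected step is a step that the limit leaves unreadable from compound 3 to compound 4 and this is only an estimate. Compound 4 is estimated at 20000 nM within a range from 7000 nM to 60000 nM and it will most likely be reported as a limit again.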

Compound 4, half-maximal inhibitory concentration: 8400 nM
Estimate against measurement, compound 4: 2.4-fold (0.38 log units) above; low and high end bracket the measured number.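

In this assay, among the compounds shown here, compound 4 gives 8400 nM, the first exact value in this set, so a carbonyl carbon carrying 4-bromophenyl can give a readable result on the shared core. Against the three earlier compounds, the change reads as an at least 1.1-fold lower number from compound 3 to compound 4 (0.07 log units; that floor lies within the scatter), as an at least 1.1-fold lower number from compound 2 to compound 4 (0.07 log units; that floor lies within the scatter) and as an at least 1.1-fold lower number from compound 1 to compound 4 (0.07 log units; that floor lies within the scatter); each of these is only a floor, so the true size of each step remains unknown and no real difference has been demonstrated. Compound 1, compound 2 and compound 3 each stand at a limit and not at a number, and the steps among them cannot be read: the limit of > 10000 nM in this assay, at which 3 of the 4 values shown sit.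

The compounds shown leave open whether the exact value goes with the bromine or with the aromatic ring itself, and how a plain phenyl or a 4-chlorophenyl on the same carbonyl carbon would read. Also open, from the compounds shown here alone, is how an amine or a carboxylic acid on that ring would read in this assay.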